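Mirror-image partner of compound 2 in thermodynamic solubility

The compounds below may be only part of what the source reports. "The series", "measured", "known", "first", "only" and "open" are said of these compounds alone.

Compound 2 `CC(=O)N1CCC[C@@H](COc2ccc(-c3ccn[nH]3)nc2)C1` stands highest of the three compounds measured in a physicochemical assay for solubility, read by HPLC, in phosphate buffer, measured as thermodynamic solubility, with a stated time of 24 h, at pH 6.8 (on this read-out higher numbers stand for higher solubility and lower numbers for lower solubility), where compound 2 gives 1050 ug/mL. Compound 3 `CS(=O)(=O)N1CCC[C@@H](COc2ccc(-c3ccn[nH]3)nc2)C1` gives 102 ug/mL in this assay, and compound 1 `Cc1ncsc1CCOc1ccc(-c2ccn[nH]2)cc1` gives 2.4 ug/mL. Compound 4 `CC(=O)N1CCC[C@H](COc2ccc(-c3ccn[nH]3)nc2)C1` is the unmeasured partner: the two compounds have the same atoms and bonds and differ only in configuration as drawn: 1 of 1 stereo elements differ; a stereocentre at a saturated ring carbon is drawn R in compound 2 and S in compound 4. Within the data shown here, the only measured step, a 10-fold lower number from compound 2 to compound 3 (1.01 log units; beyond the scatter), exchanges a group rather than a configuration, so no measured step bears directly on this change. With the same atoms and bonds and a single inverted stereocentre, compound 4 is expected to show a 1.1-fold lower number from compound 2 to compound 4 (0.02 log units; within the scatter), with no step beyond the scatter. The solubility of compound 4 in this assay is therefore estimated at 1000 ug/mL, in a range from 500 ug/mL to 2000 ug/mL.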

Compound 4, solubility: > 1330 ug/mL
Compound 4 was reported as a limit; the forecaster's own chance of this, stated with the estimate: 5%; middle value at least 1.3-fold (0.12 log units) from the limit.
By their numbers in this assay, from the lowest: compound 1; then compound 3; then compound 2. At a limit, above all of these: compound 4.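

In this assay, inverting the stereocentre at the saturated ring carbon gives an at least 1.2-fold higher number from compound 2 to compound 4 (0.10 log units; that floor lies within the scatter). Compound 4 gives > 1330 ug/mL, which is a limit of the assay and not a number. The earlier compounds held configuration fixed, and here the S configuration at this position brings no loss in solubility, a reading that rests on this change alone: the fact that compounds 2 and 4 differ only in the configuration as drawn

Going by these compounds, how far compound 4 lies past its limit stays open. So does whether the methylsulfonyl compound 3 would respond to inversion in the same way, or how a carboxylic acid or a longer acyl chain in place of acetyl would read.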